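Swapping the aryl group on the amine of compound 2

The source may hold more compounds than are shown below. What is called first, only, known or untested is meant among the compounds shown, and "the series" means these compounds.

Compound 1: `Cc1ccc(Nc2cc(NC(=O)Nc3c(Cl)cccc3Cl)ncn2)cc1F`, 45.3%
Compound 2: `CCc1ccc(Nc2cc(NC(=O)Nc3cc(OC)cc(OC)c3)ncn2)cc1`, 32.7%

In a functional assay on NCI-H1581 cells (Homo sapiens) for inhibition, read by MTT assay, with a stated time of 48 h, tested at 10 uM (on this read-out lower numbers stand for less inhibition and higher numbers for more inhibition at the one concentration tested (going by the name of the read-out)), compound 1 gives 45.3%, while compound 2 gives 32.7%, the lower of the two numbers, and the gap between them lies beyond the usual scatter. Compound 3 is `COc1cc(NC(=O)Nc2cc(Nc3cc(F)ccc3OC)ncn2)cc(OC)c1`. It differs from compound 2 in one place: 5-fluoro-2-methoxyphenyl in place of 4-ethylphenyl on a nitrogen on an aromatic ring. Within the data shown here, no measured pair shows this change directly, so the size of the step from compound 2 to compound 3 in this assay is uncertain; a small rise is expected, close to the scatter. Compound 3 is expected to give 38%, within 20% to 58%, an expected step of a number 5.3 percentage points higher from compound 2 to compound 3 (within the scatter).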

Compound 3, a percentage reported as inhibition, at one concentration (the size of the read-out at that concentration, not a potency): 42.1%
Compound 3: middle estimate off by 4.1 percentage points, on the low side; measured number inside the range.
By their numbers in this assay, from the lowest: compounds 2, 3 and 1 (each within the scatter of the next, the first and the last beyond it).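

In this assay, putting 5-fluoro-2-methoxyphenyl in place of 4-ethylphenyl on this nitrogen gives a number 9.4 percentage points higher from compound 2 to compound 3 (within the scatter). This position therefore accepts a ring carrying a methoxy group and a fluorine in place of an ethyl-bearing ring, with no change beyond the scatter. No measured evidence here accounts for the step. As far as these compounds go, the methoxy group and the fluorine enter together, and what each does alone stays open. Also open, from the compounds shown here alone, is how an unsubstituted phenyl or a phenyl bearing a carboxylic acid would read at this position.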